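A few compounds are considered here, and "the series" means these few. Any claim that something is new, unique, unknown or untested is made for them only; others in the source may bear on it.

In a functional assay on A549 cells (Homo sapiens) for antiproliferative activity, read by MTT assay, with a stated time of 72 h (a lower number here means a stronger inhibitor, a higher number a weaker inhibitor), compound 3 `O=C(N/N=C/c1ccccc1)Nc1ccc(Oc2ccnc3[nH]ccc23)cc1` gives 17200 nM. Compound 2 `O=C(N/N=C/c1cc(Br)c(O)c(Br)c1)Nc1ccc(Oc2ccnc3[nH]ccc23)c(F)c1` gives 16200 nM, within the scatter of compound 3. Compound 1 `O=C(N/N=C/c1ccccc1)Nc1ccc(Oc2ccnc3[nH]ccc23)c(F)c1` gives 2500 nM, a number clearly lower than those of the other two.

Compound 4 `O=C(N/N=C/c1ccc(O)cc1Br)Nc1ccc(Oc2ccnc3[nH]ccc23)cc1` keeps the core of compound 3 and changes one group, on a carbon with a double bond to nitrogen, where 2-bromo-4-hydroxyphenyl stands in place of phenyl: 2-bromo-4-hydroxyphenyl in place of phenyl on a carbon with a double bond to nitrogen.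

The closest measured precedent is a 6.5-fold higher number from compound 1 to compound 2 (0.81 log units; beyond the scatter), a modest step beyond the scatter, seen with 3,5-dibromo-4-hydroxyphenyl in place of phenyl at the same place. The other measured step, a 6.9-fold higher number from compound 1 to compound 3 (0.84 log units; beyond the scatter), is of similar size but concerns hydrogen in place of fluoro, a change that separates compound 4 from neither compound 3 nor its own core. It therefore offers no direct guide here.

Within the data shown here, no measured step starts from compound 3, and the group in compound 4 is not the one in compound 2, so the precedent carries over only loosely. Resting on a 6.5-fold higher number from compound 1 to compound 2 (0.81 log units; beyond the scatter), a rise in the number is expected, probably smaller than that precedent. The expected step is a 1.9-fold higher number from compound 3 to compound 4 (0.28 log units; within the scatter). For compound 4 the estimate is 33000 nM, with an expected range of 11000 nM to 90000 nM.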

Compound 4, half-maximal inhibitory concentration: 5080 nM
Beside the measured number, compound 4's estimate is 6.5-fold (0.81 log units) above it; measured number outside the range, below it.
By their numbers in this assay, from the lowest: compound 1; then compound 4; then compounds 2 and 3 (each within the scatter of the next).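

Read in this assay, the new result, a 3.4-fold lower number from compound 3 to compound 4 (0.53 log units; beyond the scatter), shows that replacing phenyl on a carbon with a double bond to nitrogen can lower the number, so a substituted phenyl at this place need not weaken the compound. Among these compounds, the only earlier step at this place, a 6.5-fold higher number from compound 1 to compound 2 (0.81 log units; beyond the scatter), ran the opposite way, but it brought in 3,5-dibromo-4-hydroxyphenyl and started from the fluoro-bearing compound 1, so the two steps differ in both the entering group and the core that carries it. Nothing measured here bears on what lies behind the new step.

The compounds shown leave open whether the opposite directions of the two steps follow from the entering group or from the fluoro substituent on the core, and whether 2-bromo-4-hydroxyphenyl would lower the number on the core of compound 1 as well. They also leave open how much of the new step belongs to the bromine and how much to the hydroxyl, and what an amine or a carboxylic acid on the same phenyl ring would do.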